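A few compounds are considered here, and "the series" means these few. Any claim that something is new, unique, unknown or untested is made for them only; others in the source may bear on it.

Compound 1 `CC1=C(C)C(=O)C(C(CCCCCCCC(=O)O)c2ccccc2)=C(C)C1=O`: 3400 nM
Compound 2 `CC1=C(C)C(=O)C(C(CCCCCC(=O)O)c2ccccc2C)=C(C)C1=O`: 3200 nM

Only these two compounds have been measured so far in a functional assay (aorta) with Oryctolagus cuniculus as the target; on this read-out higher numbers stand for weaker inhibition and lower numbers for stronger inhibition. On this read-out, compound 2 gives 3200 nM and compound 1 gives 3400 nM, so the two values lie within the scatter of each other. Compound 2 therefore stands level with compound 1, and neither can be ranked above the other.

The next compound is compound 3 `CC1=C(C)C(=O)C(C(CCCCCC(=O)O)c2cccc(F)c2)=C(C)C1=O`. It keeps the shared core and has 3-fluorophenyl in place of 2-methylphenyl on a saturated chain carbon bound to a double-bonded ring carbon and a saturated chain carbon.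

Among the compounds with values here, no two measured compounds differ in one place only, so the data offer no direct measure of what such an exchange does. Within the data shown here, the structures of compound 1 and compound 2 differ in more than one place, yet their values stay within the scatter, and this is the only guide available. A change beyond the scatter in this assay is therefore not expected. The expected change is a 1.1-fold lower number from compound 2 to compound 3 (0.03 log units; within the scatter).

For compound 3 the estimated value is 3000 nM, with an expected range from 1200 nM to 7500 nM.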

Compound 3, half-maximal inhibitory concentration: 1900 nM
Estimate against measurement, compound 3: 1.6-fold (0.20 log units) above; the range from low to high includes it.
By their numbers in this assay, from the lowest: compounds 3, 2 and 1 (each within the scatter of the next).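

In this assay, the exchange of 2-methylphenyl for 3-fluorophenyl on a saturated chain carbon bound to a double-bonded ring carbon and a saturated chain carbon gives a 1.7-fold lower number from compound 2 to compound 3 (0.23 log units; within the scatter) and provides the only direct comparison at this place among the compounds shown. This single exchange shows that the methyl-bearing aromatic ring can give way to the fluorine-bearing one with no change beyond the scatter, which compound 1 and compound 2 could not show because they differ in more than one place. The exchange alters both the atom on the ring and its location, so the two contributions cannot be separated, and nothing available accounts for the result.

The compounds shown leave open whether this place would also stay within the scatter with a group of another kind, such as pyridyl or cyclohexyl, in place of 3-fluorophenyl. They also leave open what a longer chain does on its own, since the chain of compound 1 never changes by itself with the aromatic group held constant.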